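This account rests on a few compounds, and the source may have more. Where it says the series, first, only, none or still open, it means among the compounds named here.

Measured compounds, with the inhibition constant in an assay on cells for inhibition of Nicotinamide N-methyltransferase (Homo sapiens), read by fluorescence and coupled enzyme assay, with a stated time of 10 min, in the presence of a further agent that is not named here; a lower number here means a stronger inhibitor, a higher number a weaker inhibitor:

compound 1 `NC(=O)c1cccc(CCCN(CCC[C@H](N)C(=O)O)C[C@H]2O[C@@H](n3cnc4c(N)ncnc43)[C@H](O)[C@@H]2O)c1` gives 3000 nM
compound 2 `Nc1ncnc2c1ncn2[C@@H]1O[C@H](CN(CCCc2ccc3ccccc3c2)CC[C@H](N)C(=O)O)[C@@H](O)[C@H]1O` gives 4000 nM
compound 3 `COc1ccc(C(N)=O)cc1C#CCN(CC[C@H](N)C(=O)O)C[C@H]1O[C@@H](n2cnc3c(N)ncnc32)[C@H](O)[C@@H]1O` gives 52 nM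

Compound 1 stands second highest of the three numbers. Compound 2 lies nearest, and the gap between the two falls within the usual scatter, so no order between them can be read. Compound 3 lies furthest, with a much lower number that is clearly beyond the scatter; compound 3 differs from compound 1 in more than one place, so only the two values themselves can be compared.

Compound 4 `NC(=O)c1cccc(CCCCN(CCC[C@H](N)C(=O)O)C[C@H]2O[C@@H](n3cnc4c(N)ncnc43)[C@H](O)[C@@H]2O)c1` has not yet been measured. It differs from compound 1 in one place: 3-carbamoylbenzyl in place of 3-carbamoylphenyl on a saturated chain carbon, three bonds along the chain from an amine nitrogen. The chain between the aromatic ring and the amine nitrogen is thus longer by one saturated carbon, the carboxamide-bearing ring itself being unchanged. Going by the values given here, no pair of measured compounds shows this kind of change, so the size of the step has to be judged without a precedent. Lengthening a saturated chain by one unit, with nothing else altered, is expected to move the number little, if at all, beyond the scatter. Compound 4 is therefore expected at about 4000 nM, with a likely range from 1500 nM to 10000 nM, the expected step being a 1.3-fold higher number from compound 1 to compound 4 (0.12 log units; within the scatter).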

Compound 4, inhibition constant: 540 nM
Compound 4: middle estimate off by 7.4-fold (0.87 log units), on the high side; the measured number lies below the stated range.
By their numbers in this assay, from the lowest: compound 3; then compound 4; then compounds 1 and 2 (each within the scatter of the next).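

In this assay the place on a saturated chain carbon, three bonds along the chain from an amine nitrogen, proves sensitive to the length of the chain: 3-carbamoylbenzyl in place of 3-carbamoylphenyl gives a 5.6-fold lower number from compound 1 to compound 4 (0.74 log units; beyond the scatter) with the rest of the structure unchanged. Going by these compounds alone, this is the first pair that differs in one place, and it shows that the number can move beyond the scatter even though the ring, the carboxamide and the counted hydrogen-bond donors and acceptors stay the same. Nothing measured here accounts for the size or direction of this step.

With a single step, the compounds shown leave open whether a longer chain than that of compound 4 would continue the same direction or reverse it, and whether the same lengthening would give a similar step on other versions of the shared core. Also open, going by these compounds, is what the ring substituent contributes at this chain length, as a carboxylic acid or a nitrile in place of the carboxamide would test.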